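The source may report more compounds than this note shows. Statements on the series, on what has been measured and on what is new or still open speak of the compounds shown alone.

Compound 1 `O=C(O)CCCSCCN1C(=O)OC[C@@H]1/C=C/[C@@H](O)Cc1cccc(C(F)(F)F)c1`: 0.631 L/kg
Compound 2 `CCCc1cccc(C[C@H](O)/C=C/[C@H]2CSC(=O)N2CCSCCCC(=O)O)c1`: 1.28 L/kg
Compound 3 `Cc1cccc(C[C@H](O)/C=C/[C@H]2CCC(=S)N2CCSCCCC(=O)O)c1`: 1.76 L/kg

In an in vivo ADME assay on the whole organism for pharmacokinetics, with Rattus norvegicus as the target (a lower number here means that more of the compound stays in the plasma, a higher number that more of the compound sits outside the plasma), compound 2 gives 1.28 L/kg. Compound 3 at 1.76 L/kg lies within the scatter of that number, and compound 1 at 0.631 L/kg lies lower, beyond the scatter.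

Next in the series is compound 4 `COCc1cccc(C[C@H](O)/C=C/[C@H]2CSC(=O)N2CCSCCCC(=O)O)c1`, which departs from compound 2 in one place: methoxy in place of ethyl on a saturated chain carbon bound to an aromatic carbon. That is methoxy in place of ethyl on a saturated chain carbon bound to an aromatic carbon, or, cut one bond further out, propyl to methoxymethyl.

Among the measured compounds shown here, no two measured compounds differ in one place, so the series gives no direct precedent for this change. For the measured compounds named here, the only guide is the narrow spread of the three values, from compound 1 at 0.631 L/kg to compound 3 at 1.76 L/kg. A small downward move is expected, and the estimated step of a 1.3-fold lower number from compound 2 to compound 4 (0.11 log units; within the scatter) stays within the scatter. For compound 4 the estimate is 1 L/kg, with an expected range of 0.6 L/kg to 1.7 L/kg.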

Compound 4, volume of distribution at steady state: 0.325 L/kg
The estimate for compound 4 lay 3.1-fold (0.49 log units) above the measured number; the measured number lies below the stated range.
By their numbers in this assay, from the lowest: compounds 4 and 1 (each within the scatter of the next); then compounds 2 and 3 (each within the scatter of the next).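

Methoxy in place of ethyl on a saturated chain carbon bound to an aromatic carbon gives a 3.9-fold lower number from compound 2 to compound 4 (0.60 log units; beyond the scatter) in this assay, so this position, untested by the earlier compounds, is not silent in this read-out. Among the compounds shown here, the change leaves the heavy-atom count at two, swapping one carbon for one oxygen and adding one hydrogen-bond acceptor, and this single pair is the only one-place comparison. Nothing measured here accounts for the size of the step.

From the compounds shown here alone, whether the step follows the oxygen itself or holds only for this pair remains open, as does its behaviour on the other cores. A hydroxyl, an amine or a longer ether chain at this place would test how far the trend extends.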